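The compounds below may be only part of what the source reports. "The series", "measured", "known", "first", "only" and "open" are said of these compounds alone.

Of the compounds shown here, three have been tested so far, all in a functional assay on COLO 205 cells (Homo sapiens) for inhibition, read by sulforhodamine B assay, with a stated time of 48 h, tested at 50 uM; on this read-out lower numbers stand for less inhibition of growth and higher numbers for more inhibition of growth at the one concentration tested. Compound 1 `COc1cc(/C=C/C(=O)/C=C/c2ccco2)ccc1OCc1cn(CCCOc2cc(=O)oc3ccccc23)nn1` gives 59%. Compound 2 `COc1ccccc1/C=C/C(=O)/C=C/c1ccc(OCc2cn(CCCOc3cc(=O)oc4ccccc34)nn2)c(OC)c1` shares the core of compound 1 and differs from it in a single place: 2-methoxyphenyl in place of furan-2-yl on a double-bonded chain carbon bound to a double-bonded chain carbon. In this assay compound 2 gives 57%, so the step of a number 2 percentage points lower from compound 1 to compound 2 (within the scatter) lies within the scatter of repeated measurements, and the two compounds cannot be told apart on this read-out. Compound 3 `COc1cc(/C=C/C(=O)/C=C/c2ccco2)ccc1OCc1cn(CCCCOc2cc(=O)oc3ccccc23)nn1` is built on a different core; how that core differs from the core of compound 1 is not broken down here. In this assay compound 3 gives 43%, the lowest of the three numbers, and it stands beyond the scatter from both compound 1 and compound 2.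

Compound 4 `COc1ccccc1/C=C/C(=O)/C=C/c1ccc(OCc2cn(CCCCOc3cc(=O)oc4ccccc34)nn2)c(OC)c1` has not yet been measured. For the measured compounds named here, it stands to compound 3 as compound 2 stands to compound 1: the one change is 2-methoxyphenyl in place of furan-2-yl on a double-bonded chain carbon bound to a double-bonded chain carbon, the same change at the same place that has already been made once. Going by the values given here, since that change made only a number 2 percentage points lower from compound 1 to compound 2 (within the scatter) in the single pair where it has been seen, an equally small step is expected here. For compound 4 the step is estimated at a number 1 percentage points lower from compound 3 to compound 4 (within the scatter). Compound 4 is therefore expected to give about 42%, with a range from 30% to 54% that allows for the scatter of a single-concentration read-out. Whether the change behaves the same way on the core of compound 3 as it did on the core of compound 1 is what the measurement will show.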

Compound 4, percent growth inhibition at one concentration: 47%
For compound 4 the middle estimate is 5 percentage points below the measured one, and the stated range covers the measured number.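

On the second core, putting 2-methoxyphenyl in place of furan-2-yl in this assay gives a number 4 percentage points higher from compound 3 to compound 4 (within the scatter). Set beside the first time this change was seen, the two steps cannot be told apart: the same change on two cores in this assay, a number 2 percentage points lower (within the scatter) from compound 1 to compound 2 and a number 4 percentage points higher (within the scatter) from compound 3 to compound 4, 6 percentage points apart, within the scatter of two such steps

So on these two cores the swap can be carried from one to the other, and in neither pair does it produce a step that stands clear of the scatter, even though a larger ring with a methoxy group enters in place of the smaller furan ring. This does not show that the change is without any effect, since a small real effect could be hidden in the scatter of a read-out taken at one concentration, and two pairs say nothing about how the change would behave on other cores.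

The compounds shown leave open what happens when something quite different stands at this place on the chain, for example a phenyl ring carrying an amine or a carboxylic acid instead of a methoxy group. They also leave open whether the swap would stay this quiet on a core with a longer chain.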